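Chalcone series: swapping the aryl ketone substituent

The source may hold more compounds than are shown below. What is called first, only, known or untested is meant among the compounds shown, and "the series" means these compounds.

The shared core carries a methoxy-substituted stilbene arm joined through an enone to a second aromatic ring. Compound 1 `CCCCCCCCCCCCOc1ccc(C(=O)/C=C/c2c(/C=C/c3ccc(OC)cc3)cc(OC)cc2OC)cc1` gives 12.7 ug/mL in a functional assay on B16-F10 cells (Mus musculus) for antiproliferative activity, read by MTT assay, with a stated time of 48 h; on this read-out lower numbers stand for stronger inhibition and higher numbers for weaker inhibition. Going by the values given here, compound 2 `CCCCCCOc1ccc(C(=O)/C=C/c2c(/C=C/c3ccc(OC)cc3)cc(OC)cc2OC)cc1` gives 10.4 ug/mL in this assay, and the step of a 1.2-fold lower number from compound 1 to compound 2 (0.09 log units; within the scatter) is the only one-point comparison measured so far. Compound 3 `COc1ccc(/C=C/c2cc(OC)cc(OC)c2/C=C/C(=O)c2cccc(Cl)c2)cc1` gives 3.3 ug/mL in this assay and stands lowest of the three numbers, a gap beyond the scatter from both compound 2 and compound 1.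

Compound 4 `COc1ccc(/C=C/c2cc(OC)cc(OC)c2/C=C/C(=O)c2ccc(C)cc2C)cc1` is the next member. Its change from compound 3 is 2,4-dimethylphenyl in place of 3-chlorophenyl on a carbonyl carbon. Among the compounds with values here, none of the measured steps touches this end of the molecule: the step from compound 1 to compound 2 concerns the alkoxy chain on the other aromatic ring and is within the scatter, so it does not inform the replacement of the 3-chlorophenyl group. The two remaining pairs, compound 3 against compound 1 and compound 3 against compound 2, differ in more than one place and only show that the ring attached to the carbonyl carbon can move the number beyond the scatter.

Within the data shown here, with no directly bearing step, the expected step of a 1.4-fold higher number from compound 3 to compound 4 (0.13 log units; within the scatter) is set near zero with a wide spread. Compound 4 is therefore estimated at 4.5 ug/mL in this assay, within the range 1.8 ug/mL to 14 ug/mL.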

Compound 4, half-maximal inhibitory concentration: 4 ug/mL
Compound 4: middle estimate off by 1.1-fold (0.05 log units), on the high side, within the range that was stated.
By their numbers in this assay, from the lowest: compounds 3 and 4 (each within the scatter of the next); then compounds 2 and 1 (each within the scatter of the next).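

Going by these compounds alone, the change of ring on the carbonyl carbon gives a 1.2-fold higher number from compound 3 to compound 4 (0.08 log units; within the scatter) in this assay and is the first measured step at this end of the molecule. The swap is not a small one in its atoms: 2,4-dimethylphenyl in place of 3-chlorophenyl loses the chlorine and brings in two methyl groups, going from 7 heavy atoms to 8 with no hydrogen-bond donor or acceptor on either side, yet the two compounds cannot be told apart in this assay and this position accepts both aryl groups without a step beyond the scatter. No measurement at hand offers an explanation for this result.

Within the data shown here, the single step changes the chlorine and both methyl groups together, and what each of them contributes alone stays unresolved. Also open, going by these compounds, is whether the number at this carbonyl carbon holds once the ring carries something of a different kind, such as an amine or a carboxylic acid, or a longer chain like the hexyl and dodecyl ethers on the ring of compound 2 and compound 1.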